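The compounds below may be only part of what the source reports. "The series", "measured", "known", "first", "only" and "open" are said of these compounds alone.

Values so far in a functional assay on HepG2 cells (Homo sapiens) for inhibition, read by MTT assay, with a stated time of 48 h; on this read-out lower numbers stand for stronger inhibition and higher numbers for weaker inhibition
- compound 1 `CCOC(=O)C1=C(N/N=C(/C#N)C(=O)OCC)Nc2[nH]nc(C)c2C1c1ccc(N(C)C)cc1` gives 46400 nM
- compound 2 `CCOC(=O)C1=C(NN=C(C#N)C#N)Nc2[nH]nc(C)c2C1c1ccc(N(C)C)cc1` gives 13700 nM

Within the data shown here, compound 2 holds the lower of the two numbers, and compound 1 is its only neighbour. Moving on to compound 3 `CCOC(=O)C1=C(N/N=C(/Br)c2ccccc2)Nc2[nH]nc(C)c2C1c1ccc(N(C)C)cc1`, the change is a group of 9 heavy atoms (7 carbon, 1 nitrogen, 1 bromine; one six-membered aromatic ring of carbon only) in place of a group of 6 heavy atoms (3 carbon, 3 nitrogen; no ring), on an amine nitrogen and sits on the same amine nitrogen as the one measured step. That step, a 3.4-fold lower number from compound 1 to compound 2 (0.53 log units; beyond the scatter), is modest and went with a group of 6 heavy atoms replacing a group of 9 heavy atoms. Neither group in that step has a ring, so it is a weak guide here. Compound 3 returns to a group of 9 heavy atoms, so a modest rise is expected in this assay, with wide uncertainty. The expected step is a 2.2-fold higher number from compound 2 to compound 3 (0.34 log units; beyond the scatter) in the estimate. For compound 3 the estimated value is 30000 nM, with an expected range from 9000 nM to 90000 nM in this series.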

Compound 3, half-maximal inhibitory concentration: 72000 nM
Beside the measured number, compound 3's estimate is 2.4-fold (0.38 log units) below it; measured number inside the range.
By their numbers in this assay, from the lowest: compound 2; then compounds 1 and 3 (each within the scatter of the next).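

In this assay, the group carrying one six-membered aromatic ring of carbon only, set on the amine nitrogen, gives a 5.3-fold higher number from compound 2 to compound 3 (0.72 log units; beyond the scatter), which leaves compound 2 with the lowest number of the three. Against the other group of 9 heavy atoms, which has no ring, the same change gives a 1.6-fold higher number from compound 1 to compound 3 (0.19 log units; within the scatter), so among these compounds the smaller group of 6 heavy atoms alone stands apart, while two quite different groups of equal heavy-atom count cannot be told apart. No evidence is available that accounts for this result.

Going by these compounds, whether the lower number of compound 2 follows from the size of its group or from its nitrile groups stays open, since these features change together here. A small group without nitrile, such as a methyl or an acetyl on this amine nitrogen, would separate the two.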